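The compounds below may be only part of what the source reports. "The series", "measured", "known", "first", "only" and "open" are said of these compounds alone.

Three compounds of this series have numbers from a functional assay on MIA cells (Homo sapiens) for inhibition, read by MTT assay, with a stated time of 72 h (on this read-out lower numbers stand for stronger inhibition of growth and higher numbers for weaker inhibition of growth), so far. Compound 1 `N#C/C(=C\c1ccc([N+](=O)[O-])cc1)C(=O)c1c[nH]c2ccccc12` gives a value of 46000 nM there. Compound 2 `N#C/C(=C\c1c[nH]c2ccccc12)C(=O)c1c[nH]c2ccccc12` gives a value of 14000 nM there. Compound 3 `COc1ccc(CNC(=O)/C(C#N)=C/c2ccco2)cc1` gives a value of 34000 nM there and holds the second highest number of the three: compound 1 lies within the scatter of it, while compound 2 sits at a lower number beyond the scatter. Compound 4 `COc1ccc(CNC(=O)/C(C#N)=C/c2ccc(Cl)o2)cc1` has not been measured. It differs from compound 3 by chloro in place of hydrogen on an aromatic carbon only, chloro in place of hydrogen on an aromatic carbon. Among the compounds with values here, no measured pair carries this change, so no step size is known for it. The expected step is a 1.3-fold lower number from compound 3 to compound 4 (0.10 log units; within the scatter) and amounts to none beyond the scatter. Compound 4 is therefore estimated at 27000 nM with a range from 8000 nM to 90000 nM in all.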

Compound 4, concentration for 50% growth inhibition: 15000 nM
The estimate for compound 4 lay 1.8-fold (0.26 log units) above the measured number; measured number inside the range.
By their numbers in this assay, from the lowest: compounds 2 and 4 (each within the scatter of the next); then compounds 3 and 1 (each within the scatter of the next).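

In this assay, furan-2-yl to 5-chlorofuran-2-yl gives a 2.3-fold lower number from compound 3 to compound 4 (0.36 log units; beyond the scatter), the first one-place step read in this series. It shows that the furan carbon next to the ring oxygen accepts chloro and that this change improves growth inhibition modestly, beyond the scatter. Nothing at hand accounts for the size of this step.

Open, going by these compounds, is whether bromo, methyl or an amine at this carbon would move the number as chloro does. Also open, on these data alone, is whether the step holds when the rest of compound 4 changes.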